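The compounds below may be only part of what the source reports. "The series", "measured", "known", "first", "only" and "open" are said of these compounds alone.

Among the compounds with values here, compound 2 `O=C(CNC(=O)c1nn(-c2ccccc2)c(=O)c2ccccc12)Nc1nc2ccc(F)cc2s1` gives 470 nM in an assay on L cells for inhibition of Protein-serine O-palmitoleoyltransferase porcupine (Mus musculus), read by reporter gene assay, with a stated time of 24 h (a higher number here means that more compound is needed for the effect, a lower number that less compound is needed), the higher of the two numbers measured so far, while compound 1 `Cc1ccc2nc(NC(=O)CNC(=O)c3nn(-c4ccccc4)c(=O)c4ccccc34)sc2c1` gives 35 nM. Within the data shown here, the only measured step bearing on the next change is a 13-fold higher number from compound 1 to compound 2 (1.13 log units; beyond the scatter). Compound 3 `O=C(CNC(=O)c1nn(-c2ccccc2)c(=O)c2ccccc12)Nc1nc2ccccc2s1` carries hydrogen in place of fluoro on an aromatic carbon, on an aromatic carbon of a six-membered aromatic ring of carbon only, part of a fused system of two rings. Because a 13-fold higher number from compound 1 to compound 2 (1.13 log units; beyond the scatter) shows only that methyl and fluoro differ, not where bare hydrogen sits, compound 3 is expected to land between them, at an estimated 150 nM in this assay, within 50 nM to 500 nM, a step of a 3.1-fold lower number from compound 2 to compound 3 (0.50 log units; beyond the scatter).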

Compound 3, half-maximal effective concentration: 2600 nM
Compound 3: the middle estimate sits 17-fold (1.24 log units) below what was measured, outside the stated range (above it).
By their numbers in this assay, from the lowest: compound 1; then compound 2; then compound 3.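

Hydrogen on this aromatic carbon lies outside the pair of substituents rather than inside it: the change brings a 5.5-fold higher number from compound 2 to compound 3 (0.74 log units; beyond the scatter) and a 74-fold higher number from compound 1 to compound 3 (1.87 log units; beyond the scatter) and so gives the highest number of the three. Fluoro, which looked like a loss against methyl, is therefore a gain over the unsubstituted ring. No measurement given here accounts for this order. From the compounds shown here alone, whether chloro, methoxy or an amine on the same carbon would match methyl stays open, as does whether ethyl or a longer chain would improve on it.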